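This account rests on a few compounds, and the source may have more. Where it says the series, first, only, none or still open, it means among the compounds named here.

In an ADME assay on microsomes from liver (Mus musculus) for metabolic stability, read by LC-MS, with NADPH named in the record, with a stated time of 60 min, tested at 1 uM, in the absence of a further agent (on this read-out higher numbers stand for a more stable compound and lower numbers for a less stable compound), three compounds with the same core have been measured, and none yields an exact number. Compound 1 (`COc1ccc(-c2c(C)nc3c(N4CC[C@@H](NS(C)(=O)=O)C4)cc(C)nn23)cc1OC`), with methyl on the sulfonyl sulfur, gives > 95%, which is a limit. Compound 2 (`COc1ccc(-c2c(C)nc3c(N4CC[C@@H](NS(=O)(=O)C(C)C)C4)cc(C)nn23)cc1OC`), with isopropyl there, gives > 95%, again a limit. Compound 3 (`COc1ccc(-c2c(C)nc3c(N4CC[C@@H](NS(=O)(=O)c5ccccc5)C4)cc(C)nn23)cc1OC`), with phenyl there, gives > 95%, likewise a limit, so it stands with the other two at the limit of > 95% in this assay, at which 3 of the 3 values shown sit.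

Compound 4 (`COc1ccc(-c2c(C)nc3c(N4CC[C@@H](NS(=O)(=O)c5ccc(NC(C)=O)cc5)C4)cc(C)nn23)cc1OC`) departs from compound 3 through (acetamido in place of hydrogen on an aromatic carbon), turning phenyl into 4-acetamidophenyl. Going by the values given here, three measured steps concern the group on the sulfonyl sulfur: a step that the two limits leave unreadable from compound 1 to compound 2, a step that the two limits leave unreadable from compound 1 to compound 3 and a step that the two limits leave unreadable from compound 2 to compound 3. None has a readable size, and none involves acetamido, so they offer only weak guidance.

In this assay, the expected outcome is a number at least 2 percentage points lower from compound 3 to compound 4 (that floor lies within the scatter), with no change beyond the scatter anticipated, and any shift could be read only downward because of the limit of > 95% in this assay, at which 3 of the 3 values shown sit. Compound 4 is estimated at 93%, with an expected range of 78% to 100%.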

Compound 4, percent of the compound remaining: > 95%
Compound 4 was reported as a limit; the forecaster's own chance of this, stated with the estimate: 60%; middle value at least 2 percentage points away from the limit.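

In this assay compound 4 gives > 95%, which is a limit. Going by these compounds alone, no step from compound 1, compound 2 or compound 3 to compound 4 can be read: the limit of > 95% in this assay, at which 4 of the 4 values shown sit. The compounds shown leave open whether the group on the sulfonyl sulfur changes the percent of compound remaining at all.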